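Fluoro to methyl on the aryl piperazine of compound 3

The source may hold more compounds than are shown below. What is called first, only, known or untested is meant among the compounds shown, and "the series" means these compounds.

Measured so far in a functional assay on the whole organism (Abdomen, strain Swiss) for inhibition, with Mus musculus as the target, with stated times of 30 min, 10 min and 5 min, at a dose of 20 mg/kg by the oral route; a higher number here means a stronger effect of the compound at the dose given, a lower number a weaker effect:
- compound 1 `C/C=C/c1c(C)nn(CCCN2CCN(c3ccc(C)cc3)CC2)c(=O)c1N` gives 44%
- compound 2 `Cc1c(C#N)c(-c2ccccc2)nn1CCCN1CCN(c2cccc(Cl)c2)CC1` gives 0%
- compound 3 `CC(=O)c1cccn1CCCN1CCN(c2ccc(F)cc2)CC1` gives 16%

Compound 3 stands second highest of the three numbers in this assay; its nearest neighbour is compound 2, whose number is lower by more than the scatter, while compound 1 lies furthest away with a number higher by more than the scatter. For the measured compounds named here, the three compounds share the propyl-linked aryl piperazine but differ in their cores, so no step between them can be read as a single change.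

Compound 4 `CC(=O)c1cccn1CCCN1CCN(c2ccc(C)cc2)CC1` keeps the core of compound 3 and differs from it by methyl in place of fluoro on an aromatic carbon. Compound 1 also carries the 4-methylphenyl group, yet its core is another one, so it cannot settle the size of this step. The step from compound 3 to compound 4 is expected to be small, likely within the scatter or a modest rise, as a number 6 percentage points higher from compound 3 to compound 4 (within the scatter). Compound 4 is thus estimated to give 22% in this assay, with a range from 5% to 45%.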

Compound 4, a percentage reported as inhibition, in the whole organism at one dose (the size of the read-out at that dose, not a potency): 7%
The estimate for compound 4 lay 15 percentage points above the measured number; the range from low to high includes it.
By their numbers in this assay, from the lowest: compounds 2, 4 and 3 (each within the scatter of the next, the first and the last beyond it); then compound 1.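

In this assay, for the compounds shown here, methyl in place of fluoro on the shared core gives a number 9 percentage points lower from compound 3 to compound 4 (within the scatter), the first step that can be read at a single place. At this position, on an aromatic carbon para to a large group, the read-out at this dose does not separate 4-fluorophenyl from 4-methylphenyl on this core, and whether the same holds on the core of compound 1 cannot be told from these numbers. No measurement at hand bears on the reason for this result.

Open, on these data alone, is how a methoxy group, an amine or a carboxylic acid in place of fluoro at this position would read in this assay. Also open, as far as these compounds go, is how a longer chain in place of the propyl linker would read on this core.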